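The compounds below may be only part of what the source reports. "The series", "measured", "known", "first", "only" and "open" are said of these compounds alone.

Among the measured compounds shown here, compound 1 `Cc1nc(NC(=O)c2ccccc2)c2nn(-c3ccccc3)cc2n1` is the stronger of the two compounds measured so far in an assay on CHO cells for displacement of a labelled ligand from adenosine receptor A3 (Homo sapiens), read by scintillation counting, with a stated time of 60 min; on this read-out lower numbers stand for stronger inhibition and higher numbers for weaker inhibition. Compound 1 gives 5.6 nM, the lowest of the two numbers, and compound 2 `Cc1nc(N(C(=O)c2ccccc2)C(=O)c2ccccc2)c2nn(-c3ccccc3)cc2n1` gives 33 nM. For the measured compounds named here, the only change between them is benzoyl in place of hydrogen on an amide-type nitrogen, and that step, a 5.9-fold higher number from compound 1 to compound 2 (0.77 log units; beyond the scatter), is a modest loss of binding strength.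

Compound 3 `Cc1nc(NC(=O)c2ccncc2)c2nn(-c3ccccc3)cc2n1` keeps the amide hydrogen of compound 1 and alters the ring on the other side of the carbonyl: pyridin-4-yl in place of phenyl on a carbonyl carbon. Going by the values given here, no measured pair shows this particular exchange, so the one known step, which touches the nitrogen rather than the carbonyl carbon, bears on it only loosely: it says that the amide region tolerates change without a collapse of binding. The expected step from compound 1 to compound 3 is therefore small, a 1.8-fold higher number from compound 1 to compound 3 (0.25 log units; within the scatter), with a slightly weaker value somewhat more likely than a stronger one. Compound 3 is estimated at 10 nM, within a range from 3 nM to 35 nM.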

Compound 3, inhibition constant: 5.2 nM
Compound 3: middle estimate off by 1.9-fold (0.28 log units), on the high side; the measured number falls inside the stated range.
By their numbers in this assay, from the lowest: compounds 3 and 1 (each within the scatter of the next); then compound 2.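

Swapping the ring on the carbonyl carbon, phenyl for pyridin-4-yl, gives in this assay a step of a 1.1-fold lower number from compound 1 to compound 3 (0.03 log units; within the scatter), so the two compounds cannot be told apart on this read-out. The new ring has a nitrogen in place of a ring carbon and so counts one hydrogen-bond acceptor where phenyl counts none, which shows that this place accepts that exchange with no measurable effect on binding, whereas adding benzoyl at the amide nitrogen gave a 5.9-fold higher number from compound 1 to compound 2 (0.77 log units; beyond the scatter). Nothing available explains why this exchange leaves the number within the scatter.

Only one replacement at this place is shown, so it remains open whether binding would hold with a ring carrying a carboxylic acid, or with a longer chain in place of the ring altogether. The methyl group and the other phenyl ring of the shared core are the same in all the compounds shown, so what an amine or another group would do at those places is also unknown.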